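The compounds below may be only part of what the source reports. "The series", "measured", "known", "first", "only" and "open" are said of these compounds alone.

Values in a functional assay on HT-29 cells (Homo sapiens) for cytotoxicity, read by sulforhodamine B assay; a lower number here means that less compound is tolerated, a higher number that more compound is tolerated:
- compound 1 `CC1=CC[C@@H]([C@@](C)(O)CCCC(C)(C)NC(=S)N/N=C\c2ccc(O)cc2)CC1` (58500 nM)
- compound 2 `CC1=CC[C@@H]([C@@](C)(O)CCCC(C)(C)NC(=S)N/N=C\c2ccccc2[N+](=O)[O-])CC1` (44400 nM)
- compound 3 `CC1=CC[C@@H]([C@@](C)(O)CCCC(C)(C)NC(=S)N/N=C\c2ccccc2Cl)CC1` (> 100000 nM as a limit of the assay, not a number)

Compound 3 has only a limit in this assay and no number (the limit of > 100000 nM in this assay, at which 1 of the 3 values shown sits). Two measured steps reach it (an at least 1.7-fold higher number from compound 1 to compound 3 (0.23 log units; that floor lies within the scatter)) and (an at least 2.2-fold higher number from compound 2 to compound 3 (0.35 log units; beyond the scatter)), so it lies beyond compound 2 but cannot be separated from compound 1.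

Compound 4 `CC1=CC[C@@H]([C@@](C)(O)CCCC(C)(C)NC(=S)N/N=C\c2cccc(Cl)c2)CC1` has 3-chlorophenyl in place of 2-chlorophenyl on a carbon with a double bond to nitrogen and keeps the same atoms, joined differently. Among the measured compounds shown here, no measured step shows this kind of change. For the measured compounds named here, the closest guides are the three exchanges of the aromatic group, and the one between two actual numbers is small (a 1.3-fold lower number from compound 1 to compound 2 (0.12 log units; within the scatter)). The chloro step from compound 2 is the only one beyond the scatter, and only its floor is known (an at least 2.2-fold higher number from compound 2 to compound 3 (0.35 log units; beyond the scatter)).

A small step is therefore expected in this assay, toward a lower number if any, and possibly none beyond the scatter. The expected step is (an at least 1.3-fold lower number from compound 3 to compound 4 (0.12 log units; that floor lies within the scatter)) on this reading. Compound 4 is estimated at 75000 nM (expected range 35000 nM to 130000 nM), with a real chance that only a limit is reported.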

Compound 4, concentration lethal to 50% of the cells: 45900 nM
Compound 4: middle estimate off by 1.6-fold (0.21 log units), on the high side, and the stated range covers the measured number.
By their numbers in this assay, from the lowest: compounds 2, 4 and 1 (each within the scatter of the next). At a limit, above all of these: compound 3.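

In this assay, the new result separates two groups with the same atoms at this position: with 3-chlorophenyl in place of 2-chlorophenyl on a carbon with a double bond to nitrogen, the step is an at least 2.1-fold lower number from compound 3 to compound 4 (0.33 log units; beyond the scatter). Compound 3 has only a limit and no number, so this step gives a floor and not a size: the limit of > 100000 nM in this assay, at which 1 of the 4 values shown sits.

The other two steps, a 1.0-fold higher number from compound 2 to compound 4 (0.01 log units; within the scatter) and a 1.3-fold lower number from compound 1 to compound 4 (0.11 log units; within the scatter), place compound 4 with the 2-nitrophenyl and 4-hydroxyphenyl compounds, so a chloro group on the phenyl ring does not by itself go with the limit reached by compound 3.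

On these data alone, the true distance between the two chlorophenyl compounds remains open, as does the standing of 4-chlorophenyl, which would complete the set of chlorophenyl groups at this position. Also open, as far as these compounds go, is whether 2-fluorophenyl or 2-methoxyphenyl would stay with compound 3 or fall with compound 4, and therefore whether the step belongs to the place of the group or to chloro alone.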